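Swapping an Amide Cap for a Pyridine Ring

The compounds below may be only part of what the source reports. "The series", "measured", "known", "first", "only" and "open" are said of these compounds alone.

In a functional assay on CWR22R cells (Homo sapiens) for antiproliferative activity, read by CCK-8 assay, with a stated time of 6 days (a lower number here means a stronger inhibitor, a higher number a weaker inhibitor), compound 1 `C[C@@H](Cn1ccc(-c2ccc(C#N)c(Cl)c2)n1)NC(=O)c1ccccc1` gives "not determined" (no result reported), so it cannot be placed on a number here. A relative, compound 2 `CC(O)c1ccc(C(=O)N[C@@H](C)Cn2ccc(-c3ccc(C#N)c(Cl)c3)n2)cc1`, carries a hydroxyethyl group on the benzoyl ring; in this assay compound 2 gives 9050 nM. Compound 3 `C[C@@H](Cn1ccc(-c2ccc(C#N)c(Cl)c2)n1)Nc1ccncc1` differs from compound 1 by pyridin-4-yl in place of benzoyl on an amine nitrogen. Among the compounds with values here, with no measured pair to lean on, the size and direction of this step in this assay are open; a shift no larger than the scatter is the plainest expectation. Compound 3 is estimated at 10000 nM, expected to fall between 2500 nM and 40000 nM.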

Compound 3, half-maximal inhibitory concentration: 11500 nM
Compound 3: middle estimate off by 1.2-fold (0.06 log units), on the low side, and the stated range covers the measured number.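

Compound 1 has no number to set against compound 3, so no step can be read between them. Going by these compounds, what pyridin-4-yl in place of benzoyl does in this assay stays open. Nothing shown offers a reason for the result.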